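Swapping the aryl group on a sulfonamide in compound 1

The compounds below may be only part of what the source reports. "The series", "measured", "known", "first", "only" and "open" are said of these compounds alone.

Compound 1, with the structure `COc1cc2nc(N3CCN(S(=O)(=O)c4ccc(Cl)cc4)CC3)nc(N)c2cc1OC`, was tested in a functional assay on PC-3 cells (Homo sapiens) for inhibition (a lower number here means a stronger inhibitor, a higher number a weaker inhibitor), where compound 1 gives 23000 nM. Two close relatives share its core and differ only in the aryl group on the sulfonyl sulfur. Compound 2, `COc1cc2nc(N3CCN(S(=O)(=O)c4ccc(Cl)s4)CC3)nc(N)c2cc1OC`, gives 25000 nM, and compound 3, `COc1cc2nc(N3CCN(S(=O)(=O)c4ccccc4[N+](=O)[O-])CC3)nc(N)c2cc1OC`, gives 35000 nM. Compound 1 has the lowest of the three numbers, yet the step from compound 1 to compound 2 is a 1.1-fold higher number from compound 1 to compound 2 (0.04 log units; within the scatter) and the step from compound 1 to compound 3 is a 1.5-fold higher number from compound 1 to compound 3 (0.18 log units; within the scatter), so none of the three can be set apart from the others.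

Compound 4, `COc1cc2nc(N3CCN(S(=O)(=O)c4cccc(C(=O)O)c4)CC3)nc(N)c2cc1OC`, is the next variation on this theme: 3-carboxyphenyl in place of 4-chlorophenyl on a sulfonyl sulfur. Among the measured compounds shown here, no measured compound carries a carboxylic acid, so the three steps above are the only guide, and each of them lies within the scatter. The expectation is therefore that compound 4 shows no step beyond the scatter, with the estimated step of a 1.3-fold higher number from compound 1 to compound 4 (0.12 log units; within the scatter). Compound 4 is thus expected to give about 30000 nM, with a likely range from 10000 nM to 90000 nM.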

Compound 4, half-maximal inhibitory concentration: 53000 nM
Beside the measured number, compound 4's estimate is 1.8-fold (0.25 log units) below it, within the range that was stated.
By their numbers in this assay, from the lowest: compounds 1, 2, 3 and 4 (each within the scatter of the next, the first and the last beyond it).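

At this place on the sulfonyl sulfur, the earlier swaps of one aryl group for another gave no step beyond the scatter, but 3-carboxyphenyl does in this assay with a 2.3-fold higher number from compound 1 to compound 4 (0.36 log units; beyond the scatter) and with a 2.1-fold higher number from compound 2 to compound 4 (0.33 log units; beyond the scatter) as well. Both steps are modest. The comparison with 2-nitrophenyl gives a 1.5-fold higher number from compound 3 to compound 4 (0.18 log units; within the scatter) and so does not set compound 4 apart from compound 3, which means that this group separates from only two of the three earlier groups.

Nothing available explains the size of these steps or links them to any property of the carboxylic acid. As far as these compounds go, it also remains open whether an amide or a methyl ester in place of the carboxylic acid, or a plain alkyl chain in place of the whole aryl group, would give a similar number.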